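Adding one methoxy to compound 1: expected step

This account rests on a few compounds, and the source may have more. Where it says the series, first, only, none or still open, it means among the compounds named here.

Measured in a functional assay on MCF7 cells (Homo sapiens) for cytotoxicity, read by MTT assay, with a stated time of 72 h; a higher number here means a weaker inhibitor, a lower number a stronger inhibitor:
- compound 1 `COc1ccccc1/C=C1\CCC/C(=C\c2cccc(OC)c2OC)C1=O`: 12000 nM
- compound 2 `COc1cccc(/C=C2\CCC/C(=C\c3cc(Cl)cc(Cl)c3)C2=O)c1OC`: 4300 nM

Compound 1 holds the higher of the two numbers, which makes it the weaker inhibitor of the pair. Unmeasured compound 3 `COc1ccc(/C=C2\CCC/C(=C\c3cccc(OC)c3OC)C2=O)c(OC)c1` differs from it by methoxy in place of hydrogen on an aromatic carbon, meta to a methoxy group and para to a large group.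

Among the compounds with values here, only one measured step bears on this change. Putting 3,5-dichlorophenyl in place of 2-methoxyphenyl gives a 2.8-fold lower number from compound 1 to compound 2 (0.45 log units; beyond the scatter), a modest move. That step exchanges the whole group, whereas compound 3 only gains a methoxy on it, so a smaller step is expected in this assay, leaning slightly towards a lower number and possibly none beyond the scatter. The expected change is a 1.2-fold lower number from compound 1 to compound 3 (0.08 log units; within the scatter). Compound 3 is estimated at 10000 nM, with an expected range of 4500 nM to 22000 nM.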

Compound 3, half-maximal inhibitory concentration: > 20000 nM
Compound 3 ended at the assay's limit (the forecaster's own chance of this, stated with the estimate: 10%); at least 2.0-fold (0.30 log units) between middle value and limit.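

In this assay compound 3 gives > 20000 nM, which is a limit of the assay and not a number. Within the data shown here, the new step reads an at least 1.6-fold higher number from compound 1 to compound 3 (0.22 log units; that floor lies within the scatter), so methoxy in place of hydrogen on an aromatic carbon, meta to a methoxy group and para to a large group, brings no lower number, whereas the only earlier step, a 2.8-fold lower number from compound 1 to compound 2 (0.45 log units; beyond the scatter), ran the other way. The new step has only a floor, and that floor lies within the scatter, so it reads as no gain rather than as a proven loss: the limit of > 20000 nM in this assay, at which 1 of the 3 values shown sits.

Open, from the compounds shown here alone, is how far past the limit compound 3 actually lies. Also open, going by these compounds, is whether an amine or a hydroxyl at this place would behave as the methoxy does, and whether the added methoxy gives the same result alongside the 3,5-dichlorophenyl group of compound 2.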